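Chloro in Place of Methyl in a Level Series

The compounds below may be only part of what the source reports. "The series", "measured", "known", "first", "only" and "open" are said of these compounds alone.

In a functional assay on HeLa cells (Homo sapiens) for cytotoxicity, read by sulforhodamine B assay, with a stated time of 48 h (a lower number here means a stronger inhibitor, a higher number a weaker inhibitor), compound 1 `C=CCOc1ccc(F)cc1C(=O)c1cccnc1` gives 93000 nM, compound 2 `C=CCOc1ccc(Br)cc1C(=O)c1cccnc1` gives 96000 nM and compound 3 `C=CCOc1ccc(C)cc1C(=O)c1cccnc1` gives 94000 nM. Compound 3 therefore stands level with the other two, all within the scatter. Compound 4 `C=CCOc1ccc(Cl)cc1C(=O)c1cccnc1` carries chloro in place of methyl on an aromatic carbon, para to an allyloxy group (chloro in place of methyl on an aromatic carbon). Going by the values given here, three measured steps bear on this change: a 1.0-fold higher number from compound 1 to compound 3 (0.00 log units; within the scatter), a 1.0-fold lower number from compound 2 to compound 3 (0.01 log units; within the scatter) and a 1.0-fold higher number from compound 1 to compound 2 (0.01 log units; within the scatter), each within the scatter. Fluoro, bromo and methyl at this place give values that cannot be separated, so no step beyond the scatter is expected. The expected step is no change at the digits printed from compound 3 to compound 4 (within the scatter). Compound 4 is estimated at 94000 nM, with an expected range from 65000 nM to 135000 nM.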

Compound 4, half-maximal inhibitory concentration: 75000 nM
For compound 4 the middle estimate is 1.3-fold (0.10 log units) above the measured one; low and high end bracket the measured number.
By their numbers in this assay, from the lowest: compounds 4, 1, 3 and 2 (each within the scatter of the next).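

In this assay chloro stays within the scatter of methyl (a 1.3-fold lower number from compound 3 to compound 4 (0.10 log units; within the scatter)), of bromo (a 1.3-fold lower number from compound 2 to compound 4 (0.11 log units; within the scatter)) and of fluoro (a 1.2-fold lower number from compound 1 to compound 4 (0.09 log units; within the scatter)). Four groups at this place, para to the allyloxy group, now give values that cannot be separated, and chloro does not break the level series. Nothing available accounts for this flatness.

The compounds shown leave open whether a group of another kind at this place, such as an amine or a carboxylic acid, would move the number beyond the scatter. They also leave open whether a longer chain in place of the allyloxy group would do so.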